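The source may report more compounds than this note shows. Statements on the series, on what has been measured and on what is new or still open speak of the compounds shown alone.

Measured so far:
Compound 1 `N[C@@H](COP(=O)(O)OCCCOC(=O)CCc1ccccc1OCc1cccc(Oc2ccccc2)c1)C(=O)O` gives 19.4%.
Compound 2 `N[C@@H](COP(=O)(O)OCCCOC(=O)CCc1ccccc1OCc1cccc(OC2CCCCC2)c1)C(=O)O` gives 18.8%.
Compound 3 `N[C@@H](COP(=O)(O)OCCCOC(=O)CCc1ccccc1OCc1cccc(Oc2cccc(Cl)c2)c1)C(=O)O` gives 17.1%.

The three compounds were compared in an assay on cells for agonist activity at probable G-protein coupled receptor 34 (Mus musculus), with a stated time of 1 h; a higher number here means a larger maximal response, a lower number a smaller maximal response. Compound 1 has the highest of the three numbers, yet its gap to compound 2, a number 0.6 percentage points lower from compound 1 to compound 2 (within the scatter), and its gap to compound 3, a number 2.3 percentage points lower from compound 1 to compound 3 (within the scatter), both stay within the scatter, so no order among the three can be claimed. The compound now to be considered is compound 4 `N[C@@H](COP(=O)(O)OCCCOC(=O)CCc1ccccc1OCc1cccc(Oc2ccc(Cl)cc2)c1)C(=O)O`, which differs from compound 1 by a single change: chloro in place of hydrogen on an aromatic carbon.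

Going by the values given here, one measured step bears directly on this change, as it also puts a chloro in place of a hydrogen on the same ring, though at a different place: a number 2.3 percentage points lower from compound 1 to compound 3 (within the scatter). The remaining steps at this part of the shared core, a number 0.6 percentage points lower from compound 1 to compound 2 (within the scatter) and a number 1.7 percentage points lower from compound 2 to compound 3 (within the scatter), are equally small. Every variation tried here has left the maximal response in this assay essentially unmoved, so no step beyond the scatter is expected in either direction for compound 4.

On that basis compound 4 is estimated at 18.5%, with a range from 13% to 24%, which corresponds to an expected step of a number 0.9 percentage points lower from compound 1 to compound 4 (within the scatter).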

Compound 4, largest response reached (Emax), in percent of the reference or control that the assay uses: 17.8%
Beside the measured number, compound 4's estimate is 0.7 percentage points above it; the measured number falls inside the stated range.
By their numbers in this assay, from the lowest: compounds 3, 4, 2 and 1 (each within the scatter of the next).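

With chloro on the aromatic carbon para to a large group, the result is a number 1.6 percentage points lower from compound 1 to compound 4 (within the scatter) in this assay and thus adds a second chloro placement on this ring that leaves compound 4 indistinguishable from compound 1. Going by these compounds alone, the two placements cannot be told apart either, since 4-chlorophenyl in place of 3-chlorophenyl gives a number 0.7 percentage points higher from compound 3 to compound 4 (within the scatter) in this assay and this comparison was not available from the earlier compounds. Setting 4-chlorophenyl in place of cyclohexyl on the same oxygen gives a number 1 percentage points lower from compound 2 to compound 4 (within the scatter) and so extends the same picture to this pair, with every step shown here remaining within the scatter.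

No information is available to explain these small steps. Still open, on these data alone, is whether a different group on this ring, such as an amine, a carboxylic acid or a methoxy group, or a longer chain elsewhere in the shared core, would produce a step beyond the scatter in the maximal response.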